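A few compounds are considered here, and "the series" means these few. Any claim that something is new, unique, unknown or untested is made for them only; others in the source may bear on it.

In a functional assay on LNCaP cells (Homo sapiens) for cytotoxicity (on this read-out lower numbers stand for stronger inhibition and higher numbers for weaker inhibition), compound 3 (`CNC(=O)Nc1ccc(-c2nc(N3CC4CCC(C3)O4)c3cnn([C@H]4CC[C@H](O)CC4)c3n2)cc1`) gives 20 nM. Compound 1 (`CNC(=O)Nc1ccc(-c2nc(N3CC4CCC(C3)O4)c3cnn([C@H]4CC[C@@H](O)CC4)c3n2)cc1`), its stereoisomer on the ring, gives 20 nM, so the two stand level and together hold the lowest of the three numbers. Compound 2 (`CCn1ncc2c(N3CC4CCC(C3)O4)nc(-c3ccc(NC(=O)NC)cc3)nc21`) gives 70 nM.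

Compound 4 (`CNC(=O)Nc1ccc(-c2nc(N3CC4CCC(C3)O4)c3cnn(C4CCC(OC)(OC)CC4)c3n2)cc1`) has not yet been measured. It keeps the shared core and changes only the group on an aromatic nitrogen: a group of 10 heavy atoms (8 carbon, 2 oxygen; one six-membered non-aromatic ring of carbon only) in place of a group of 7 heavy atoms (6 carbon, 1 oxygen; one six-membered non-aromatic ring of carbon only), on an aromatic nitrogen.

Two kinds of measured step bear on this change. Exchanging the group at that nitrogen had a modest effect, a 3.5-fold lower number from compound 2 to compound 3 (0.54 log units; beyond the scatter) when 4-hydroxycyclohexyl took the place of ethyl and a 3.5-fold higher number from compound 1 to compound 2 (0.54 log units; beyond the scatter) in the opposite exchange. Changing the drawn configuration on the ring had none, no change at the digits printed from compound 1 to compound 3 (within the scatter).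

The six-membered ring stays in compound 4, so a shift smaller than the ethyl exchange is expected, towards a higher number and hardly beyond the scatter. The expected change is a 1.8-fold higher number from compound 3 to compound 4 (0.24 log units; within the scatter). The estimate for compound 4 is 35 nM, with an expected range from 12 nM to 100 nM.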

Compound 4, half-maximal inhibitory concentration: 2 nM
Compound 4: middle estimate off by 18-fold (1.24 log units), on the high side; the measured number lies below the stated range.
By their numbers in this assay, from the lowest: compound 4; then compounds 1 and 3 (each within the scatter of the next); then compound 2.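

In this assay the position on an aromatic nitrogen responds strongly to what the six-membered ring carries, not only to whether a ring is there: with the ring kept, the exchange gives a 10-fold lower number from compound 3 to compound 4 (1.00 log units; beyond the scatter) and likewise a 10-fold lower number from compound 1 to compound 4 (1.00 log units; beyond the scatter) for the other stereoisomer. Against the ethyl group the same position now spans a 35-fold lower number from compound 2 to compound 4 (1.54 log units; beyond the scatter) in this assay, so the earlier compounds had shown only part of its range. Nothing at hand accounts for this gain.

The compounds shown do not separate the loss of the hydroxyl group from the arrival of the two methoxy groups. A cyclohexyl ring carrying a single methoxy group, or a ketone carbonyl, would bear on that question.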